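Hydroxy in Place of Morpholin-4-yl Across Two Cores

The compounds below may be only part of what the source reports. "The series", "measured", "known", "first", "only" and "open" are said of these compounds alone.

Compound 1 `Cn1ncc2cc(-c3cnccc3/C=C/C(=O)N3CCOCC3)ccc21` and compound 3 `Cn1ncc2cc(-c3cnccc3/C=C/C(=O)O)ccc21` share one core and differ by hydroxy in place of morpholin-4-yl on a carbonyl carbon. In an assay on a protein complex for inhibition of CDK8/Cyclin C (Homo sapiens), with a stated time of 1 h, tested at 10 uM (a lower number here means less inhibition, a higher number more inhibition at the concentration tested (going by the name of the read-out)), compound 1 gives 95% and compound 3 gives 102%, a step of a number 7 percentage points higher from compound 1 to compound 3 (within the scatter). Compound 2 `O=C(/C=C/c1ccncc1-c1ccc2cc[nH]c2c1)N1CCOCC1` carries the other core; the difference between the two cores is not broken down here. In this assay compound 2 gives 102%, level with compound 3 at the digits reported and within the scatter of compound 1. Compound 4 `O=C(O)/C=C/c1ccncc1-c1ccc2cc[nH]c2c1` stands to compound 2 as compound 3 stands to compound 1, the change being (hydroxy in place of morpholin-4-yl on a carbonyl carbon), the same change at the same place. For compound 4 the expected step is a number 2 percentage points lower from compound 2 to compound 4 (within the scatter), because the earlier step was a number 7 percentage points higher from compound 1 to compound 3 (within the scatter) and the number for compound 2 is already among the highest measured here. Compound 4 is estimated at 100%, between 90% and 108%.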

Compound 4, a percentage reported as inhibition, at one concentration (the size of the read-out at that concentration, not a potency): 103%
Compound 4: middle estimate off by 3 percentage points, on the low side; the measured number falls inside the stated range.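

On the core of compound 2, hydroxy in place of morpholin-4-yl on a carbonyl carbon gives a number 1 percentage points higher from compound 2 to compound 4 (within the scatter) in this assay. Set beside the same change on the core of compound 1, the two steps cannot be told apart: the same change on two cores in this assay, a number 7 percentage points higher (within the scatter) from compound 1 to compound 3 and a number 1 percentage points higher (within the scatter) from compound 2 to compound 4, 6 percentage points apart, within the scatter of two such steps. This shows that the change leaves the read-out within the scatter on both cores, but the read-out is taken at one concentration and is not a potency, so it does not show that the two groups would stay level in potency, and two cores say nothing about any other core.

The compounds shown leave open how a simple amine or a methyl ester would read in place of morpholin-4-yl at that carbonyl carbon. They also leave open whether a longer chain there would keep the read-out within the scatter on either core.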